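A few compounds are considered here, and "the series" means these few. Any claim that something is new, unique, unknown or untested is made for them only; others in the source may bear on it.

Measured so far in a functional assay on CCRF-CEM cells for agonist activity at C-X-C chemokine receptor type 4 (Homo sapiens), read by calcium flux, with a stated time of 25 min; on this read-out higher numbers stand for an effect only at larger amounts of compound and lower numbers for an effect already at smaller amounts:
- compound 1 `CN(C[C@H]1Cc2c(cccc2N2CCN(Cc3ccccn3)CC2)CN1)[C@H]1CCCc2cccnc21`: > 30000 nM, a limit of this assay, not a number.
- compound 2 `CCCN(C[C@H]1Cc2c(cccc2N2CCNCC2)CN1)[C@H]1CCCc2cccnc21`: > 30000 nM, likewise a limit.
- compound 3 `CN(C[C@H]1Cc2c(cccc2N2C[C@@H]3C[C@H]2CN3)CN1)[C@H]1CCCc2cccnc21`: > 30000 nM, likewise a limit.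

Compound 2 therefore stands nowhere that can be placed on a scale; its value is a limit, and the same holds for both other values shown, as the limit of > 30000 nM in this assay, at which 3 of the 3 values shown sit, states. Among the measured compounds shown here, no step between measured compounds can be sized from these data.

Compound 4 `c1cnc2c(c1)CCC[C@@H]2N(CC1CCCCC1)C[C@H]1Cc2c(cccc2N2CCNCC2)CN1` differs from compound 2 by cyclohexyl in place of ethyl on a saturated chain carbon bound to an amine nitrogen. With every value shown sitting at the limit, no step in either direction can be read from the measured compounds, and none is expected beyond the scatter. For compound 4 the expected step from compound 2 is a number no higher from compound 2 to compound 4 (the limit leaves the size open). Compound 4 is estimated at 30000 nM in this assay, within 10000 nM to 100000 nM, most likely again reported only as a limit.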

Compound 4, half-maximal effective concentration: > 30000 nM
Compound 4: a limit, no number; the forecaster's own chance of this, stated with the estimate: 85%; the middle value sits exactly at the limit.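

In this assay, no step can be read from compound 2 to compound 4, as both values are limits, not numbers: the limit of > 30000 nM in this assay, at which 4 of the 4 values shown sit.

The compounds shown leave open which structural change, if any, would give a readable value on this read-out.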